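Ester variation on the shared core: buffer stability notes

The source may report more compounds than this note shows. Statements on the series, on what has been measured and on what is new or still open speak of the compounds shown alone.

Read-out throughout: a physicochemical assay for metabolic stability, read by LC-MS, in phosphate buffer, with a stated time of 3 h, at pH 7.4, tested at 50 uM; on this read-out lower numbers stand for a less stable compound and higher numbers for a more stable compound.

Compound 1 `C[C@@H](O)[C@H]1C(=O)N2C(C(=O)OCOC(=O)C3CCCCC3)=C(S[C@@H]3CN[C@H](C(=O)Nc4cccc(C(=O)O)c4)C3)[C@H](C)[C@H]12`: in this assay compound 1 gives the limit > 95%.
Compound 2 `C[C@@H](O)[C@H]1C(=O)N2C(C(=O)OCOC(=O)OC3CCCCC3)=C(S[C@@H]3CN[C@H](C(=O)Nc4cccc(C(=O)O)c4)C3)[C@H](C)[C@H]12`: in this assay compound 2 gives the limit > 95%.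
Compound 3 `COC(=O)OCOC(=O)C1=C(S[C@@H]2CN[C@H](C(=O)Nc3cccc(C(=O)O)c3)C2)[C@H](C)[C@@H]2[C@@H]([C@@H](C)O)C(=O)N12`: in this assay compound 3 gives the limit > 95%.

Within the data shown here, compound 3 thus stands at the limit of this assay, not at a number; (the limit of > 95% in this assay, at which 3 of the 3 values shown sit), so no compound of the set is placed below it. The three steps among the measured compounds are all unreadable for the same reason: a step that the two limits leave unreadable from compound 1 to compound 2, a step that the two limits leave unreadable from compound 1 to compound 3 and a step that the two limits leave unreadable from compound 2 to compound 3. None of them gives a size, and none tells whether a change at the ester oxygen moves the read-out at all.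

Compound 4 `CC(C)OC(=O)C1=C(S[C@@H]2CN[C@H](C(=O)Nc3cccc(C(=O)O)c3)C2)[C@H](C)[C@@H]2[C@@H]([C@@H](C)O)C(=O)N12` differs from compound 3 by isopropyl in place of ((methoxycarbonyl)oxy)methyl on an oxygen next to a carbonyl group. Among the measured compounds shown here, no measured step bears on this change beyond showing that three different groups at this position all sit at the limit. The expectation for compound 4 is therefore a reading at or near that limit, an estimated step that the limit leaves unreadable from compound 3 to compound 4. In this assay compound 4 is estimated at 96%, within a range from 88% to 100%, most likely reported again as a limit only.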

Compound 4, percent of the compound remaining: > 95%
Compound 4 gave a limit, no number (the forecaster's own chance of this, stated with the estimate: 80%); the middle value is on the limit's open side.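

Compound 4, like compound 1, compound 2 and compound 3, gives only a limit in this assay, so none of the steps to compound 4 can be read: the limit of > 95% in this assay, at which 4 of the 4 values shown sit.

The compounds shown leave open whether isopropyl and the three acyloxymethyl-type groups on this oxygen differ at all in this assay.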